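Swapping the sulfonyl ring of compound 1

A few compounds are considered here, and "the series" means these few. Any claim that something is new, unique, unknown or untested is made for them only; others in the source may bear on it.

Three close relatives share one core and differ only in the ring on the sulfonyl sulfur. In a physicochemical assay for lipophilicity, measured as octanol-water partition, at pH 7.4 (a higher number here means a more lipophilic compound, a lower number a more polar compound), compound 1 `Cc1ccc2[nH]c(C(=O)N[C@H]3CN(S(=O)(=O)c4cccnc4)C[C@@H]3C(=O)NCCN(C)C)cc2c1` gives 1.4 as its value. Compound 2 `Cc1ccc2[nH]c(C(=O)N[C@H]3CN(S(=O)(=O)c4ccnnc4)C[C@@H]3C(=O)NCCN(C)C)cc2c1` gives 0.7 and stands clearly apart, while compound 3 `Cc1ccc2[nH]c(C(=O)N[C@H]3CN(S(=O)(=O)c4ccnc(C)c4)C[C@@H]3C(=O)NCCN(C)C)cc2c1` gives 1.7 and cannot be told from compound 1. Compound 1 therefore sits with compound 3 at the upper end of this small set.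

Compound 4 `Cc1ccc2[nH]c(C(=O)N[C@H]3CN(S(=O)(=O)c4cn(C)nc4C)C[C@@H]3C(=O)NCCN(C)C)cc2c1` has not yet been measured. Its difference from compound 1 is 1,3-dimethyl-1H-pyrazol-4-yl in place of pyridin-3-yl on a sulfonyl sulfur in a single swap: 1,3-dimethyl-1H-pyrazol-4-yl in place of pyridin-3-yl on a sulfonyl sulfur. Two measured steps replace the same ring at the same place. Pyridazin-4-yl gave a number 0.70 log units lower from compound 1 to compound 2 (beyond the scatter) and 2-methylpyridin-4-yl gave a number 0.30 log units higher from compound 1 to compound 3 (within the scatter) in these measurements. The entering ring resembles each only in part, with a further ring nitrogen like pyridazin-4-yl and methyl like 2-methylpyridin-4-yl. These two steps in this assay run in opposite directions, so the expected change is small: a number 0.10 log units lower from compound 1 to compound 4 (within the scatter) is the estimate, and nothing beyond the scatter is expected. Compound 4 is estimated at 1.3 with a likely range from 0.8 to 1.8 on this basis.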

Compound 4, distribution coefficient: 1.4
Beside the measured number, compound 4's estimate is 0.10 log units below it; low and high end bracket the measured number.
By their numbers in this assay, from the lowest: compound 2; then compounds 1, 4 and 3 (each within the scatter of the next).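

In this assay, this place on the sulfonyl sulfur takes a five-membered aromatic ring as readily as a six-membered one: the swap from pyridin-3-yl to 1,3-dimethyl-1H-pyrazol-4-yl gives no change at the digits printed from compound 1 to compound 4 (within the scatter), and the swap from 2-methylpyridin-4-yl to the same ring gives a number 0.30 log units lower from compound 3 to compound 4 (within the scatter). Two ring nitrogens do not by themselves go with the low number of compound 2, since the ring of compound 4 also holds two and the swap from pyridazin-4-yl gives a number 0.70 log units higher from compound 2 to compound 4 (beyond the scatter), which leaves compound 2 alone apart from the other three. Nothing available here explains why these rings give the numbers they do.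

Compound 4 differs from compound 2 in ring size and in its methyl groups at once, so the compounds shown cannot say which of these two differences carries the step. A plain pyrazol-4-yl ring without methyl groups, or a phenyl ring with no ring nitrogen at all, would be the kind of neighbour that could pull those parts apart.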